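From trifluoromethoxy to carbamoyl on compound 1

The source may hold more compounds than are shown below. What is called first, only, known or untested is meant among the compounds shown, and "the series" means these compounds.

In an ADME assay on Raji cells (Homo sapiens) for cytotoxicity, with a stated time of 72 h (on this read-out lower numbers stand for an effect already at smaller amounts and higher numbers for an effect only at larger amounts of compound), compound 1 `Cc1cc(NC(=O)Nc2ccccc2OC(F)(F)F)c2ccccc2n1` gives > 25000 nM as its reading, which is a limit and not a number. Compound 2 `CSc1ccc(NC(=O)Nc2cc(C)nc3ccccc23)cc1` likewise gives > 25000 nM as its reading, also a limit. The data so far show the limit of > 25000 nM in this assay, at which 2 of the 2 values shown sit, and nothing finer. Compound 3 `Cc1cc(NC(=O)Nc2ccccc2C(N)=O)c2ccccc2n1` carries carbamoyl in place of trifluoromethoxy on an aromatic carbon and otherwise matches compound 1. Within the data shown here, no measured step gauges this swap, so no shift beyond the scatter is expected. The expected change is a number no higher from compound 1 to compound 3 (the limit leaves the size open) in this estimate. For compound 3 the expected value is 25000 nM within an estimated range of 10000 nM to 40000 nM and a limit reading is likely.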

Compound 3, half-maximal effective concentration: > 25000 nM
Compound 3: only a limit was reported; the forecaster's own chance of this, stated with the estimate: 85%; the middle value lies on the limit itself.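

Compound 1 and compound 3 give no readable step, because both readings are limits and not numbers: the limit of > 25000 nM in this assay, at which 3 of the 3 values shown sit. The compounds shown leave open whether carbamoyl in place of trifluoromethoxy changes the reading at all.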